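The source may hold more compounds than are shown below. What is called first, only, known or untested is meant among the compounds shown, and "the series" means these compounds.

Measured compounds in this series:
- compound 1 `COc1ccccc1OCCNc1ccc(=O)n(Cc2ccc(OC(F)F)c(OC3CCCC3)c2)n1`: 23600 nM
- compound 2 `COc1ccccc1OCCNc1ccc(=O)n(Cc2ccc(OC(F)F)c(OCC3CC3)c2)n1`: 24400 nM
- compound 3 `COc1ccccc1OCCNc1cnn(Cc2ccc(OC(F)F)c(OCC3CC3)c2)c(=O)c1Cl`: > 100000 nM, a limit of the assay rather than a number

In a functional assay on AGS cells (Homo sapiens) for antiproliferative activity, read by MTT assay, with a stated time of 48 h (on this read-out higher numbers stand for weaker inhibition of growth and lower numbers for stronger inhibition of growth), compound 2 gives 24400 nM and compound 1 gives 23600 nM. The step is a 1.0-fold lower number from compound 2 to compound 1 (0.01 log units; within the scatter), the change being (cyclopentyl in place of cyclopropylmethyl on an oxygen on an aromatic ring). Compound 3 reaches only a limit, > 100000 nM, and sits at the limit of > 100000 nM in this assay, at which 1 of the 3 values shown sits. How the core of compound 3 differs from that of compound 2 is not broken down here.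

Compound 4 `COc1ccccc1OCCNc1cnn(Cc2ccc(OC(F)F)c(OC3CCCC3)c2)c(=O)c1Cl` carries the same change made on compound 3: cyclopentyl in place of cyclopropylmethyl on an oxygen on an aromatic ring. Since the earlier step, a 1.0-fold lower number from compound 2 to compound 1 (0.01 log units; within the scatter), lay within the scatter, the step from compound 3 to compound 4 is expected to be a step that the limit leaves unreadable from compound 3 to compound 4. Compound 4 is therefore estimated at 150000 nM in this assay, within 60000 nM to 400000 nM, most likely again reported only as a limit.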

Compound 4, concentration for 50% growth inhibition: > 100000 nM
Compound 4 gave a limit, no number (the forecaster's own chance of this, stated with the estimate: 75%); the middle value lies beyond the limit too.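

Compound 3 and compound 4 both stand only as limits, so no step can be read between them: the limit of > 100000 nM in this assay, at which 2 of the 4 values shown sit. Going by these compounds, whether cyclopentyl in place of cyclopropylmethyl changes anything on the core of compound 3 stays open.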